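Pyridinyl in place of difluorophenyl on the sulfoxide

The source may hold more compounds than are shown below. What is called first, only, known or untested is meant among the compounds shown, and "the series" means these compounds.

Within the data shown here, compound 1, `CC(O)(C[S+]([O-])c1ccc(F)cc1F)C(=O)Nc1ccc([N+](=O)[O-])cc1C(F)(F)F`, is the only compound here with a numerical result: in a functional assay on LNCaP cells (Homo sapiens) for antiproliferative activity (on this read-out lower numbers stand for stronger inhibition and higher numbers for weaker inhibition), compound 1 gives 24400 nM. Compound 2, `CC(O)(C[S+]([O-])c1ccccn1)C(=O)Nc1ccc(C#N)c(C(F)(F)F)c1`, is known only as a limit of the assay; in this assay compound 2 gives > 100000 nM, and that number is a limit rather than a measurement. The shared core thus spans a wide stretch, with compound 1 as the single fixed point and the limit of > 100000 nM in this assay, at which 1 of the 2 values shown sits, marking the other end.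

Compound 3, `CC(O)(C[S+]([O-])c1ccccn1)C(=O)Nc1ccc([N+](=O)[O-])cc1C(F)(F)F`, has not yet been measured. It differs from compound 1 in one place: pyridin-2-yl in place of 2,4-difluorophenyl on a sulfur. Among the measured compounds shown here, no step between measured compounds covers this change, but compound 2 also carries pyridin-2-yl on a sulfur.

The step of a 2.5-fold higher number from compound 1 to compound 3 (0.39 log units; beyond the scatter) is expected to fall in the direction of weaker inhibition and beyond the usual scatter, because compound 2 sits at the limit of > 100000 nM in this assay, at which 1 of the 2 values shown sits. Compound 3 is estimated at 60000 nM, with a range from 20000 nM to 150000 nM.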

Compound 3, half-maximal inhibitory concentration: > 100000 nM
Compound 3: no number, only a limit (the forecaster's own chance of this, stated with the estimate: 40%); at least 1.6-fold (0.22 log units) between middle value and limit.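

Among these compounds, this pair gives the first direct reading of the group on the sulfur, since compound 2 carries pyridin-2-yl but differs from compound 1 in more than that one place. In this assay, pyridin-2-yl in place of 2,4-difluorophenyl on a sulfur gives an at least 4.0-fold higher number from compound 1 to compound 3 (0.61 log units; beyond the scatter), so on the core of compound 1 this single change alone weakens inhibition beyond the scatter, and the true size of the step may be larger because compound 3 is known only as a limit of the assay. The only measured number in the set therefore belongs to the compound with 2,4-difluorophenyl, while both compounds with pyridin-2-yl on a sulfur stand at one shared limit: the limit of > 100000 nM in this assay, at which 2 of the 3 values shown sit.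

The change swaps a ring of carbon only with two fluorine atoms for a ring with one nitrogen and no fluorine, so the compounds shown cannot tell which of these differences carries the step. Nor do they show how an unsubstituted phenyl or a pyridin-3-yl on the same sulfur would behave, or how far the step extends past the limit.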